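From a sulfanyl linker to a fluorophenoxy one

The source may report more compounds than this note shows. Statements on the series, on what has been measured and on what is new or still open speak of the compounds shown alone.

Compound 3 `COc1ccc(Sc2nc3cc(N)cc(N)c3nc2-c2ccccc2)cc1` stands at a limit in a functional assay on Hs-578T cells (Homo sapiens) for inhibition, read by sulforhodamine B assay, with a stated time of 48 h; on this read-out higher numbers stand for weaker inhibition of growth and lower numbers for stronger inhibition of growth: it gives only < 100000 nM, a limit of the assay rather than a number (the limit of < 100000 nM in this assay, at which 1 of the 3 values shown sits). Compound 1 `Nc1cc(N)c2nc(-c3ccccc3)c(NCc3ccc(F)cc3)nc2c1` gives 4900 nM, and compound 2 `COc1ccc(CNc2nc3cc(N)cc(N)c3nc2-c2ccccc2)cc1` gives 26900 nM. The change to compound 4 `Nc1cc(N)c2nc(-c3ccccc3)c(Oc3ccc(F)cc3)nc2c1` is 4-fluorophenoxy in place of (4-methoxyphenyl)sulfanyl on an aromatic carbon. Among the measured compounds shown here, two measured steps bear on it. The step of a 5.5-fold higher number from compound 1 to compound 2 (0.74 log units; beyond the scatter) shows that fluoro is kinder to growth inhibition than methoxy, which favours compound 4. The step that the limit leaves unreadable from compound 1 to compound 3 says nothing about the linker exchange. Compound 4 is therefore expected at 30000 nM, between 5000 nM and 100000 nM, an estimated step that the limit leaves unreadable from compound 3 to compound 4 of uncertain size.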

Compound 4, concentration for 50% growth inhibition: 20000 nM
Beside the measured number, compound 4's estimate is 1.5-fold (0.18 log units) above it, and the stated range covers the measured number.
By their numbers in this assay, from the lowest: compound 1; then compounds 4 and 2 (each within the scatter of the next).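

In this assay, 4-fluorophenoxy in place of (4-fluorobenzyl)amino on this carbon next to the ring nitrogen gives a 4.1-fold higher number from compound 1 to compound 4 (0.61 log units; beyond the scatter), so a ring joined through oxygen still gives a readable number, though the amino-linked compound 1 inhibits growth more strongly. The step from compound 3 cannot be read, because the value of compound 3 is a limit and not a number: the limit of < 100000 nM in this assay, at which 1 of the 4 values shown sits.

The compounds shown leave open whether the linking atom or the length of the link sets the step from compound 1. A 4-fluoroanilino or a 4-fluorobenzyloxy group on this carbon would separate the two.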